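The source may hold more compounds than are shown below. What is called first, only, known or untested is meant among the compounds shown, and "the series" means these compounds.

Measured so far in a functional assay on KYSE-70 cells for antiproliferative activity against KYSE-70 cell line (Homo sapiens), read by MTT assay, with a stated time of 72 h; a higher number here means a weaker inhibitor, a lower number a stronger inhibitor:
- compound 1 `O=C(Nc1ccc(F)cc1)c1cc(=O)[nH]c2cc(Br)ccc12`: > 20000 nM, a limit, not a number.
- compound 2 `O=C(Nc1cccc(F)c1)c1cc(=O)[nH]c2cc(F)ccc12`: > 20000 nM, a limit, not a number.
- compound 3 `O=C(Nc1cc(F)cc(F)c1)c1cc(=O)[nH]c2cc(Cl)ccc12`: 9000 nM.

Compound 2 stands at the limit of > 20000 nM in this assay, at which 2 of the 3 values shown sit. For the measured compounds named here, no step between two measured compounds is given, so nothing here sets a scale for the change to compound 4 `Cc1cc(-c2ccc3c(C(=O)Nc4cccc(F)c4)cc(=O)[nH]c3c2)c(C)cc1F`.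

The change: 4-fluoro-2,5-dimethylphenyl in place of fluoro on an aromatic carbon. A much larger aromatic substituent enters where a single fluoro sat. With no measured step of this kind in the series, the direction is open; a gain beyond the scatter is expected but uncertain, so the step of an at least 3.3-fold lower number from compound 2 to compound 4 (0.52 log units; beyond the scatter) is an estimate toward stronger inhibition. Compound 4 is thus estimated at 6000 nM, within 1500 nM to 20000 nM.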

Compound 4, half-maximal inhibitory concentration: > 20000 nM
Compound 4: only a limit was reported; the forecaster's own chance of this, stated with the estimate: 35%; middle value at least 3.3-fold (0.52 log units) from the limit.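

Compound 2 and compound 4 are both reported only as limits, so no step between them can be read: the limit of > 20000 nM in this assay, at which 3 of the 4 values shown sit.

From the compounds shown here alone, whether 4-fluoro-2,5-dimethylphenyl in place of fluoro changes the activity at all remains open.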